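Carboxythiophene in place of pyridine on the ring amine

The source may hold more compounds than are shown below. What is called first, only, known or untested is meant among the compounds shown, and "the series" means these compounds.

Measured compounds:
- compound 1, `Clc1cc(Cl)cc(CO[C@H]2CCCN(Cc3cccnc3)[C@H]2c2ccccc2)c1`: 112000 nM
- compound 2, `OC[C@@H](O[C@H]1CCCN(Cc2ccccc2Cc2nnco2)[C@H]1c1ccccc1)c1cc(Cl)cc(Cl)c1`: 3700 nM
- compound 3, `COC(=O)Nn1c(C[C@H]2CCC[C@H](OCc3cc(C(F)(F)F)cc(C(F)(F)F)c3)[C@@H]2c2ccccc2)n[nH]c1=O`: 4500 nM

In an assay on isolated protein for activation of cGMP-dependent protein kinase 1 (Homo sapiens), read by ADP-Glo, with stated times of 120 min and 40 min (on this read-out lower numbers stand for an effect already at smaller amounts and higher numbers for an effect only at larger amounts of compound), compound 1 gives 112000 nM, the highest of the three numbers shown. Compound 3 comes nearest, with a number lower by more than the scatter, and compound 2 lies furthest, also lower by more than the scatter. Compound 1 is therefore the weakest of the three measured compounds.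

Compound 4, `O=C(O)c1ccc(CN2CCC[C@H](OCc3cc(Cl)cc(Cl)c3)[C@@H]2c2ccccc2)s1`, has not yet been measured. It differs from compound 1 in one place: 5-carboxythiophen-2-yl in place of pyridin-3-yl on a saturated chain carbon bound to an amine nitrogen in a ring. Going by the values given here, no pair of measured compounds shows exactly this kind of change, so the size of the step cannot be read from the data. Compound 2 and compound 3 carry other groups on the same side of the shared core and give lower numbers than compound 1, which hints that changes here can matter. The expectation for compound 4 is a lower number than for compound 1, in a step of a 3.7-fold lower number from compound 1 to compound 4 (0.57 log units; beyond the scatter) that is estimated to lie beyond the scatter, though with much uncertainty. Compound 4 is expected to give about 30000 nM, within a range from 6000 nM to 150000 nM.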

Compound 4, half-maximal effective concentration: 76000 nM
Estimate against measurement, compound 4: 2.5-fold (0.40 log units) below; the measured number falls inside the stated range.
By their numbers in this assay, from the lowest: compounds 2 and 3 (each within the scatter of the next); then compounds 4 and 1 (each within the scatter of the next).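

Going by these compounds alone, at the position on a saturated chain carbon bound to an amine nitrogen in a ring, a single exchange can now be read for the first time: in this assay, 5-carboxythiophen-2-yl in place of pyridin-3-yl gives a 1.5-fold lower number from compound 1 to compound 4 (0.17 log units; within the scatter). A different aromatic ring that also brings a hydrogen-bond donor can therefore sit here without a shift larger than repeated measurements would produce. Nothing measured here explains this outcome.

The ring and the carboxylic acid changed together, so the compounds shown cannot separate them; a plain thiophen-2-yl, or a pyridin-3-yl carrying a carboxylic acid, would pull the two apart. Also open, on these data alone, is whether a primary amine in place of the carboxylic acid, or a longer chain holding it, would move the number beyond the scatter.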